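Working notes on cytotoxicity across four analogues

This account rests on a few compounds, and the source may have more. Where it says the series, first, only, none or still open, it means among the compounds named here.

Measured in an ADME assay on HepG2 cells (Homo sapiens) for cytotoxicity, read by luminescence, CellTiter-Glo and ATP content, with a stated time of 72 h (on this read-out lower numbers stand for an effect already at smaller amounts and higher numbers for an effect only at larger amounts of compound), so far:
compound 1 `COc1cccc(Oc2ccc3c(NCCCNCc4cc(F)ccc4OC)ccnc3c2)c1` gives 7100 nM
compound 2 `COc1cccc(Oc2ccc3c(NCCCNCc4ccco4)ccnc3c2)c1` gives 15500 nM
compound 3 `COc1cccc(Oc2ccc3c(NCCCNCc4cccc(OC)c4O)ccnc3c2)c1` gives 5300 nM

Compound 2 stands at the highest number of the three: a 2.2-fold higher number from compound 1 to compound 2 (0.34 log units; beyond the scatter) and a 2.9-fold lower number from compound 2 to compound 3 (0.47 log units; beyond the scatter) both lie beyond the scatter, while the gap between compound 1 and compound 3 does not: a 1.3-fold lower number from compound 1 to compound 3 (0.13 log units; within the scatter).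

Compound 4 `CC(C)CCc1ccc2c(NCCCNCc3ccco3)ccnc2c1` has not been measured. It differs from compound 2 in one place: isopentyl in place of 3-methoxyphenoxy on an aromatic carbon. For the measured compounds named here, every measured step instead changes the group on a saturated chain carbon bound to an amine nitrogen, and none touches this aromatic carbon, so no measured step bears on this change. With nothing to guide direction, a step of roughly scatter size is expected: a 1.0-fold lower number from compound 2 to compound 4 (0.01 log units; within the scatter). Compound 4 is therefore estimated at 15000 nM, with a wide range from 4000 nM to 50000 nM.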

Compound 4, half-maximal effective concentration: 11200 nM
Compound 4: middle estimate off by 1.3-fold (0.13 log units), on the high side; low and high end bracket the measured number.
By their numbers in this assay, from the lowest: compounds 3, 1, 4 and 2 (each within the scatter of the next, the first and the last beyond it).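

For the compounds shown here, this is the only measured change on this aromatic carbon: in this assay, isopentyl in place of 3-methoxyphenoxy gives a 1.4-fold lower number from compound 2 to compound 4 (0.14 log units; within the scatter) and so stays within the scatter. With furan-2-yl held constant, the six-membered aromatic ring and the hydrogen-bond acceptors of the leaving group can therefore be lost without a step beyond the scatter. No measured evidence accounts for this result.

On these data alone, it remains open whether the same change stays within the scatter with the amine side chains of compound 1 and compound 3. Also open, as far as these compounds go, is how a primary amine or a carboxylic acid on this aromatic carbon would read.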